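Benzyl or phenyl on the piperazine nitrogen: a small series

A few compounds are considered here, and "the series" means these few. Any claim that something is new, unique, unknown or untested is made for them only; others in the source may bear on it.

Three compounds share one core and differ only in the group on an amine nitrogen in a ring. Compound 1 `CCCn1c(=O)[nH]c2nc(-c3ccc(S(=O)(=O)N4CCN(Cc5ccc(Br)cc5)CC4)cc3)[nH]c2c1=O` gives 28% in an assay on CHO cells for displacement of a labelled ligand from adenosine receptor A3 (Homo sapiens), read by scintillation counting, with a stated time of 45 min, tested at 1 uM, in the presence of a further agent that is not named here (a lower number here means less inhibition, a higher number more inhibition at the concentration tested (going by the name of the read-out)), compound 2 `CCCn1c(=O)[nH]c2nc(-c3ccc(S(=O)(=O)N4CCN(c5ccccc5)CC4)cc3)[nH]c2c1=O` gives 27%, and compound 3 `CCCn1c(=O)[nH]c2nc(-c3ccc(S(=O)(=O)N4CCN(c5ccc(I)cc5)CC4)cc3)[nH]c2c1=O` gives 36%. The three numbers lie close together: the steps of a number 8 percentage points higher from compound 1 to compound 3 (within the scatter) and a number 9 percentage points higher from compound 2 to compound 3 (within the scatter) are both within the scatter, as is a number 1 percentage points lower from compound 1 to compound 2 (within the scatter). Compound 4 `CCCn1c(=O)[nH]c2nc(-c3ccc(S(=O)(=O)N4CCN(Cc5cccc(C)c5)CC4)cc3)[nH]c2c1=O` is not yet measured; it differs from compound 3 by 3-methylbenzyl in place of 4-iodophenyl on an amine nitrogen in a ring. The step of a number 8 percentage points higher from compound 1 to compound 3 (within the scatter) bears on this change most directly, since it traded a benzyl for a phenyl, and it stayed within the scatter. He therefore expects a step of a number 6 percentage points lower from compound 3 to compound 4 (within the scatter), no more than the scatter. For compound 4 he estimates 30%, between 18% and 42%.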

Compound 4, a percentage reported as inhibition, at one concentration (the size of the read-out at that concentration, not a potency): 17%
Compound 4: middle estimate off by 13 percentage points, on the high side; measured number outside the range, below it.
By their numbers in this assay, from the lowest: compounds 4, 2, 1 and 3 (each within the scatter of the next, the first and the last beyond it).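

Among the compounds shown here, with 3-methylbenzyl on the amine nitrogen in a ring, this position shows steps beyond the scatter for the first time: a number 19 percentage points lower from compound 3 to compound 4 (beyond the scatter) and a number 11 percentage points lower from compound 1 to compound 4 (beyond the scatter). The second of these keeps the benzyl and changes only its ring substituent, so the substituent alone can shift the read-out, whereas a number 10 percentage points lower from compound 2 to compound 4 (within the scatter) leaves compound 2 and compound 4 unseparated. Nothing available explains the result.

On these data alone, how an unsubstituted benzyl or a 3-methylphenyl directly on the nitrogen would read remains open, and with it whether the methyl or the benzyl carries the step.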